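Trimming the amine of compound 1 to a pyrrolidine

A few compounds are considered here, and "the series" means these few. Any claim that something is new, unique, unknown or untested is made for them only; others in the source may bear on it.

Compound 1 `c1ccc2c(c1)CCN(c1ccnc(Nc3ccc(Oc4ncnc5ccsc45)cc3)n1)C2` has the lower of the two measured numbers in a functional assay on MDA-MB-231 cells (Homo sapiens) for inhibition, read by MTT assay, with a stated time of 72 h, tested at 20 uM (a lower number here means less inhibition, a higher number more inhibition at the concentration tested (going by the name of the read-out)), where compound 1 gives 15.4%. Compound 2 `CNC(=O)c1cc(Oc2ccc(Nc3nccc(N4CCc5ccccc5C4)n3)cc2)ccn1` differs from it at the aryl ether and gives 41.2%; that step, a number 25.8 percentage points higher from compound 1 to compound 2 (beyond the scatter), concerns a different part of the molecule. Compound 3 `c1cc(N2CCCC2)nc(Nc2ccc(Oc3ncnc4ccsc34)cc2)n1` is the one still to be measured. The change from compound 1 to compound 3 is pyrrolidin-1-yl in place of 1,2,3,4-tetrahydroisoquinolin-2-yl on an aromatic carbon. Within the data shown here, no measured step alters this amine, so nothing in the data bears directly on the change; the one step known, from compound 1 to compound 2, touches the other end of the shared core. Without such precedent, the step of a number 1.6 percentage points higher from compound 1 to compound 3 (within the scatter) is expected to stay within the scatter. For compound 3 the estimate in this assay is 17%, with a range from 3% to 35%.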

Compound 3, a percentage reported as inhibition, at one concentration (the size of the read-out at that concentration, not a potency): 14.3%
Beside the measured number, compound 3's estimate is 2.7 percentage points above it; the measured number falls inside the stated range.
By their numbers in this assay, from the lowest: compounds 3 and 1 (each within the scatter of the next); then compound 2.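

In this assay, among these compounds, pyrrolidin-1-yl in place of 1,2,3,4-tetrahydroisoquinolin-2-yl on this aromatic carbon gives a number 1.1 percentage points lower from compound 1 to compound 3 (within the scatter), the first reading of any change at this position. With the aryl ether group held constant, the six-membered aromatic ring of carbon only can therefore go, along with the six-membered non-aromatic ring, without the number leaving the scatter. No independent measurement is available to explain this result.

Both compounds in this pair sit low in the assay, so the comparison says little about how this amine would behave in a compound with a higher number, such as compound 2. Also open, as far as these compounds go, is whether a morpholine, a piperidine or an open-chain dimethylamino group on this carbon would shift the number beyond the scatter.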